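A Thiophene Sulfonyl in Place of the Nitrogen Methyl

The compounds below may be only part of what the source reports. "The series", "measured", "known", "first", "only" and "open" are said of these compounds alone.

Measured compounds:
compound 1 `COc1ccc(-c2cc(=O)c3c(OC)cc(OC)cc3n2C)cc1`: 28000 nM
compound 2 `COc1ccc(-c2cc(=O)c3c(OC)cc(OC)cc3n2S(=O)(=O)c2ccc(C)cc2)cc1`: > 44800 nM (a limit of the assay, not a number)

In a functional assay on SUP-B15 cells (Homo sapiens) for antiproliferative activity, with a stated time of 72 h (on this read-out lower numbers stand for an effect already at smaller amounts and higher numbers for an effect only at larger amounts of compound), compound 1 gives 28000 nM, the only number shown in this set. Compound 2 reaches only a limit, > 44800 nM. Among the compounds with values here, the single measured step is an at least 1.6-fold higher number from compound 1 to compound 2 (0.20 log units; that floor lies within the scatter); its floor is set by the limit of > 44800 nM in this assay, at which 1 of the 2 values shown sits.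

Compound 3 `COc1ccc(-c2cc(=O)c3c(OC)cc(OC)cc3n2S(=O)(=O)c2ccc(Br)s2)cc1` also carries a sulfonyl on the aromatic nitrogen of the shared core. (5-bromothiophen-2-yl)sulfonyl in place of methyl on an aromatic nitrogen

Within the data shown here, the one step that bears on this change replaced the same methyl with an aryl sulfonyl and gave a higher number, though its floor lies within the scatter. The same or a larger upward step, or none beyond the scatter, is therefore expected for compound 3 in this assay. Compound 3 is estimated at 50000 nM, within 22000 nM to 120000 nM, and the expected step is a 1.8-fold higher number from compound 1 to compound 3 (0.25 log units; within the scatter), with a real chance that only a limit is reported.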

Compound 3, half-maximal effective concentration: > 48200 nM
Compound 3: only a limit was reported; the forecaster's own chance of this, stated with the estimate: 60%; the middle value is on the limit's open side.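

In this assay, compound 3 also ends in a limit rather than a number, > 48200 nM. Exchanging the methyl on the aromatic nitrogen for (5-bromothiophen-2-yl)sulfonyl gives an at least 1.7-fold higher number from compound 1 to compound 3 (0.23 log units; that floor lies within the scatter), so a sulfonyl carrying a five-membered aromatic ring, like the (4-methylphenyl)sulfonyl of compound 2, has yielded no number, and the floor of this step is set by a limit: the limit of > 48200 nM in this assay, at which 1 of the 3 values shown sits. The step from compound 2 to compound 3 cannot be read, as both values are limits, so the two sulfonyl aryl groups cannot be ranked.

From the compounds shown here alone, how far either sulfonyl compound truly lies from compound 1 remains open, as both floors fall within the scatter. Also open, going by these compounds, is what other groups on this nitrogen would give, such as an ethyl group, an acetyl group or a chain ending in an amine.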